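Aryl esters on a triterpenoid diol: the fluorophenyl case

The compounds below may be only part of what the source reports. "The series", "measured", "known", "first", "only" and "open" are said of these compounds alone.

Of the compounds shown here, three of the shared core have been tested in a functional assay on MCF7 cells (Homo sapiens) for antiproliferative activity, read by MTT assay, with a stated time of 72 h; on this read-out higher numbers stand for weaker inhibition and lower numbers for stronger inhibition. Compound 1 `CC1=CC[C@H]2[C@@H]1CC=C(C)[C@@H](CCC1=C(C)CC[C@@H]3OC(C)(C)[C@@H](O)CC[C@@]13C)C2(C)C` sits at a limit of the assay, with > 50000 nM. Compound 2 `CC1=CC[C@H]2[C@H](CC[C@]2(C)O)C(C)(C)[C@@H]1CC[C@H]1[C@]2(C)CC[C@H](OC(=O)CCC(=O)O)C(C)(C)O[C@H]2CC[C@@]1(C)O` carries a succinate ester on its pyran ring and in this assay also reaches only a limit, > 50000 nM. Going by the values given here, compound 3 `CC1=CC[C@H]2[C@H](CC[C@]2(C)O)C(C)(C)[C@@H]1CC[C@H]1[C@]2(C)CC[C@H](OC(=O)c3ccc([N+](=O)[O-])cc3)C(C)(C)O[C@H]2CC[C@@]1(C)O` replaces that ester with a nitrobenzoate and is the only member with a number: in this assay compound 3 gives 21600 nM. Among the compounds with values here, the one step that can be counted is an at least 2.3-fold lower number from compound 2 to compound 3 (0.36 log units; beyond the scatter); it is bounded by the limit of > 50000 nM in this assay, at which 2 of the 3 values shown sit, so its true size is open-ended.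

Compound 4 `CC1=CC[C@H]2[C@H](CC[C@]2(C)O)C(C)(C)[C@@H]1CC[C@H]1[C@]2(C)CC[C@H](OC(=O)c3ccccc3F)C(C)(C)O[C@H]2CC[C@@]1(C)O` is the next variation on compound 2. Its change is 2-fluorophenyl in place of 2-carboxyethyl on a carbonyl carbon. Within the data shown here, the change keeps the ester carbonyl on the oxygen next to a carbonyl group and again puts an aromatic ring where the 2-carboxyethyl stood, so the step from compound 2 to compound 3 is the one comparison that bears on it.

On that basis compound 4 is expected to move in the same direction, with a step of an at least 2.0-fold lower number from compound 2 to compound 4 (0.30 log units; that floor lies within the scatter) to a lower number. Compound 4 is therefore estimated at about 25000 nM, most plausibly between 8000 nM and 60000 nM.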

Compound 4, half-maximal inhibitory concentration: 11300 nM
Beside the measured number, compound 4's estimate is 2.2-fold (0.34 log units) above it; the range from low to high includes it.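

In this assay, putting 2-fluorophenyl in place of 2-carboxyethyl on the carbonyl carbon gives an at least 4.4-fold lower number from compound 2 to compound 4 (0.64 log units; beyond the scatter), so compound 3 is no longer the only aromatic ester to give a number rather than a limit. A very different ring substituent gives a similar result, with a 1.9-fold lower number from compound 3 to compound 4 (0.28 log units; within the scatter): this step does not separate the two aryl esters, and neither compound 3 nor compound 4 can be ranked above the other. The full size of the step from the succinate ester remains open-ended, as compound 2 sits at a limit of the assay: the limit of > 50000 nM in this assay, at which 2 of the 4 values shown sit.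

The compounds shown leave open how an unsubstituted phenyl on the same carbonyl carbon would compare with these two groups, and whether a simple alkyl chain would also give a number. In compound 3 and compound 4 the aromatic ring enters and the carboxylic acid leaves in a single change, and the contributions of the two remain unseparated.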